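From Fluoro to Trifluoromethyl on Compound 2

The source may hold more compounds than are shown below. What is called first, only, known or untested is meant among the compounds shown, and "the series" means these compounds.

In an ADME assay on Vero cells (Chlorocebus sabaeus) for cytotoxicity, read by resazurin assay, with a stated time of 72 h (on this read-out lower numbers stand for stronger inhibition and higher numbers for weaker inhibition), compound 1 (`Cc1ccc(C(=O)CCN2CCN(c3ccc(C(F)(F)F)cc3)CC2)cc1`) gives 140000 nM and compound 2 (`O=C(CCN1CCN(c2ccc(F)cc2)CC1)c1ccc(Br)cc1`) gives 99500 nM. These two numbers lie within the usual scatter, so compound 2 cannot be separated from compound 1. Compound 3 (`O=C(CCN1CCN(c2ccc(C(F)(F)F)cc2)CC1)c1ccc(Br)cc1`) carries trifluoromethyl in place of fluoro on an aromatic carbon. Among the measured compounds shown here, no measured pair shows this change alone. Little change is expected because compound 1 with the same trifluoromethyl gives 140000 nM. The expected step of a 1.2-fold higher number from compound 2 to compound 3 (0.08 log units; within the scatter) in this assay stays within the scatter. For compound 3 the estimate is 120000 nM, with an expected range from 60000 nM to 220000 nM.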

Compound 3, half-maximal inhibitory concentration: 78800 nM
Compound 3: middle estimate off by 1.5-fold (0.18 log units), on the high side; measured number inside the range.
By their numbers in this assay, from the lowest: compounds 3, 2 and 1 (each within the scatter of the next).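

In this assay, among the compounds shown here, trifluoromethyl in place of fluoro on an aromatic carbon now has its own measured pair, giving a 1.3-fold lower number from compound 2 to compound 3 (0.10 log units; within the scatter) and so no step that can be told apart from repeat measurements. Bromo in place of methyl on an aromatic carbon gives a 1.8-fold lower number from compound 1 to compound 3 (0.25 log units; within the scatter) as well, so neither single change separates these compounds. No measurement shown here bears on why these steps are so small. As far as these compounds go, whether an amine or a carboxylic acid on this aromatic carbon would give a step beyond the scatter remains open.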